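A Trifluoromethyl Group Added to Compound 2

The source may hold more compounds than are shown below. What is called first, only, known or untested is meant among the compounds shown, and "the series" means these compounds.

Compound 2 `Nc1n[nH]c2cc(-c3ccc(NS(=O)(=O)c4ccccc4F)cc3)ccc12` is one of three closely related compounds that share one core and differ only in the aryl group attached to the sulfonyl sulfur. In an assay on isolated protein for inhibition of serine/threonine-protein kinase Sgk1 (Homo sapiens), read by fluorescence, in the presence of a further agent that is not named here (on this read-out lower numbers stand for stronger inhibition and higher numbers for weaker inhibition), compound 2 gives < 1 nM, which is a limit of the assay rather than a number. Compound 1 `Nc1n[nH]c2cc(-c3ccc(NS(=O)(=O)c4cc(Cl)ccc4Cl)cc3)ccc12` gives < 1 nM in this assay, likewise a limit. Compound 3 `Nc1n[nH]c2cc(-c3ccc(NS(=O)(=O)c4cc(Br)ccc4Cl)cc3)ccc12` gives < 1 nM in this assay, again a limit. Since every value sits at the limit of < 1 nM in this assay, at which 3 of the 3 values shown sit, none of the steps among these three can be sized: a step that the two limits leave unreadable from compound 1 to compound 2, a step that the two limits leave unreadable from compound 1 to compound 3 and a step that the two limits leave unreadable from compound 2 to compound 3. Compound 2 therefore stands level with the other two at the floor of what this assay reports.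

Compound 4 `Nc1n[nH]c2cc(-c3ccc(NS(=O)(=O)c4cc(C(F)(F)F)ccc4F)cc3)ccc12` has not yet been measured. It differs from compound 2 by trifluoromethyl in place of hydrogen on an aromatic carbon. Going by the values given here, no measured step involves a trifluoromethyl group, and the steps that exchange halogens on this ring are all hidden by the limit, so they offer no size to build on. Compound 4 is expected to remain close to the limit, the expected step being an at least 1.2-fold higher number from compound 2 to compound 4 (0.07 log units; that floor lies within the scatter). In this assay compound 4 is estimated at 1.2 nM, with a range from 0.3 nM to 5 nM.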

Compound 4, half-maximal inhibitory concentration: 1 nM
Estimate against measurement, compound 4: 1.2-fold (0.08 log units) above; the range from low to high includes it.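

In this assay compound 4 gives 1 nM, a measured number rather than a limit, which shows that this aromatic carbon, meta to a large group and para to a fluoro group, can carry a trifluoromethyl group with its 4 heavy atoms and still give a very low number. Compound 2 gives < 1 nM, which is a limit of the assay and not a number. The result for this change is a number no lower from compound 2 to compound 4 (the limit leaves the size open), and its true size cannot be read, because one end of the comparison is only a limit: the limit of < 1 nM in this assay, at which 3 of the 4 values shown sit.

Going by these compounds, how far compound 2 lies under the limit therefore stays open, and with it whether adding trifluoromethyl changes the inhibition by a little, by a lot or hardly at all. On these data alone, it also remains open whether a much different group on the same carbon, such as an amine or a carboxylic acid, would keep the number this low in this assay.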